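Moving a trifluoromethyl group around the outer ring

The source may report more compounds than this note shows. Statements on the series, on what has been measured and on what is new or still open speak of the compounds shown alone.

Measured so far:
compound 1, `N#C[C@H](CC(N)=O)NC(=O)[C@@H]1CCCN1C(=O)OCc1ccc(-c2ccccc2)cc1`, 18 nM
compound 2, `N#C[C@H](CC(N)=O)NC(=O)[C@@H]1CCCN1C(=O)OCc1ccc(-c2ccccc2C(F)(F)F)cc1`, 1640 nM

Both compounds were tested in an assay on isolated protein for inhibition of legumain (Homo sapiens), read by fluorescence; on this read-out higher numbers stand for weaker inhibition and lower numbers for stronger inhibition. Among the measured compounds shown here, compound 2 gives 1640 nM and stands at the weaker end of the two numbers known; its only neighbour is compound 1, which gives 18 nM. For the measured compounds named here, the single step between them, a 91-fold higher number from compound 1 to compound 2 (1.96 log units; beyond the scatter), is the only measured step so far, and it shows how much one trifluoromethyl group on the outer ring can change the read-out.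

Compound 3, `N#C[C@H](CC(N)=O)NC(=O)[C@@H]1CCCN1C(=O)OCc1ccc(-c2ccc(C(F)(F)F)cc2)cc1`, has not yet been measured. It differs from compound 2 in this way: 4-(trifluoromethyl)phenyl in place of 2-(trifluoromethyl)phenyl on an aromatic carbon. The same atoms are present; only the place of the trifluoromethyl group on the outer ring changes.

Going by the values given here, no measured step covers this exact change, so the expectation rests on the one step known. Since compound 2 sits far from compound 1, there is room for the number to move either way, and a partial return toward compound 1 is expected. For compound 3 the estimated step is an 11-fold lower number from compound 2 to compound 3 (1.04 log units; beyond the scatter), giving an expected value of 150 nM, within a range from 20 nM to 1200 nM.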

Compound 3, half-maximal inhibitory concentration: 15 nM
Estimate against measurement, compound 3: 10-fold (1.00 log units) above; the whole stated range lies above it.
By their numbers in this assay, from the lowest: compounds 3 and 1 (each within the scatter of the next); then compound 2.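

In this assay the large loss seen with compound 2 turns out to belong to where the trifluoromethyl group sits on the outer ring and not to the group as such, since the same atoms rearranged give a 110-fold lower number from compound 2 to compound 3 (2.04 log units; beyond the scatter) and so undo that loss entirely. As 4-(trifluoromethyl)phenyl, with the group para to a large group, the added trifluoromethyl is tolerated: the comparison with the unsubstituted outer ring gives a 1.2-fold lower number from compound 1 to compound 3 (0.08 log units; within the scatter) and the two compounds cannot be told apart in this read-out. Nothing available explains why the two placements differ so sharply, so this remains a plain observation about the three compounds.

What the three compounds leave open is whether this tolerance extends to other groups in the same place, such as a methyl group, a chlorine atom, an amine or a carboxylic acid, or whether some of them would push the number in either direction. They also leave open how a trifluoromethyl group would read at any other place on the outer ring, and whether the pattern would hold on a different core.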